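Bulking the para substituent of a potent pyrazolopyrimidine analogue

A few compounds are considered here, and "the series" means these few. Any claim that something is new, unique, unknown or untested is made for them only; others in the source may bear on it.

Of the compounds shown here, two have been measured in a functional assay on A549 cells (Homo sapiens) for inhibition, read by CCK-8 assay, with a stated time of 48 h; a lower number here means a stronger inhibitor, a higher number a weaker inhibitor. Compound 1 `COc1cc(-c2ccnc3cc(-c4c[nH]c5ccccc45)nn23)cc(OC)c1OC` carries a 1H-indol-3-yl group and in this assay compound 1 gives 29 nM. Compound 2 `COc1cc(-c2ccnc3cc(-c4ccc(C)cc4)nn23)cc(OC)c1OC` bears a 4-methylphenyl group in its place; in this assay compound 2 gives 3 nM, the lowest number of the two, with the step of a 9.7-fold lower number from compound 1 to compound 2 (0.99 log units; beyond the scatter) separating it from compound 1. Compound 3 `COc1cc(-c2ccnc3cc(-c4ccc(C(C)(C)C)cc4)nn23)cc(OC)c1OC` has not yet been measured. It differs from compound 2 in one place: tert-butyl in place of methyl on an aromatic carbon. Among the compounds with values here, the only measured step, from compound 1 to compound 2, exchanges the whole ring at that position, so it does not speak to a change in size of a group on the same 4-substituted phenyl. Within the data shown here, no measured pair shows the effect of a methyl to tert-butyl exchange here, so the expectation for compound 3 is therefore loosely held: a number estimated near that of compound 2, with a possible drift toward a weaker inhibitor that may or may not exceed the scatter, i.e. an expected step of a 2.0-fold higher number from compound 2 to compound 3 (0.30 log units; within the scatter). Compound 3 is estimated at 6 nM, within a range from 1.5 nM to 25 nM.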

Compound 3, half-maximal inhibitory concentration: > 10000 nM
Compound 3: a limit, no number; the forecaster's own chance of this, stated with the estimate: 2%; middle value at least 1600-fold (3.22 log units) away from the limit.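

In this assay compound 3 gives > 10000 nM, which is a limit of the assay and not a number: the limit of > 10000 nM in this assay, at which 1 of the 3 values shown sits.

The position therefore does not accept every 4-substituted phenyl group: the exchange of methyl for tert-butyl, made on an aromatic carbon para to a large group while the ring itself stays the same, gives an at least 3300-fold higher number from compound 2 to compound 3 (3.52 log units; beyond the scatter). The 4-(tert-butyl)phenyl group also falls behind the 1H-indol-3-yl group, with an at least 340-fold higher number from compound 1 to compound 3 (2.53 log units; beyond the scatter), so the order seen between the 1H-indol-3-yl and 4-methylphenyl groups is reversed here, and the outcome at this place depends on the substituent on the phenyl ring and not only on the ring that carries it.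

With only methyl and tert-butyl on that ring, the compounds leave open where the number begins to climb, which an ethyl or isopropyl group would help to locate, and whether a methoxy group or a chlorine atom in the same place would behave like methyl or like tert-butyl. What lies behind the rise cannot be read from these values.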